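The compounds below may be only part of what the source reports. "The series", "measured", "known", "first", "only" and "open" are said of these compounds alone.

Values in a functional assay on HepG2 cells (Homo sapiens) for inhibition, read by MTT assay, with a stated time of 24 h; on this read-out higher numbers stand for weaker inhibition of growth and lower numbers for stronger inhibition of growth:
compound 1 `COc1ccc2c(c1)c(-c1nc3ccccc3n1C(=O)c1ccccc1OC)cn2C`: 23600 nM
compound 2 `COc1ccc2c(c1)c(-c1nc3ccccc3n1C(=O)c1ccc(OC)c(OC)c1)cn2C`: 5100 nM
compound 3 `COc1ccc2c(c1)c(-c1nc3ccccc3n1C(=O)c1ccccc1Br)cn2C`: 54200 nM

Compound 3 stands highest of the three at 54200 nM, the weakest inhibition of growth measured so far. The nearer gap is a 2.3-fold higher number from compound 1 to compound 3 (0.36 log units; beyond the scatter), and the wider one is an 11-fold higher number from compound 2 to compound 3 (1.03 log units; beyond the scatter). Both lie beyond the scatter.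

The next compound is compound 4 `COc1ccc2c(c1)c(-c1nc3ccccc3n1C(=O)c1cccc(Br)c1)cn2C`, with 3-bromophenyl in place of 2-bromophenyl on a carbonyl carbon. The two have the same atoms, joined differently.

Among the compounds with values here, no measured step moves a bromo group, so the evidence is indirect. Within the data shown here, the closest precedent is a 4.6-fold lower number from compound 1 to compound 2 (0.67 log units; beyond the scatter), where 3,4-dimethoxyphenyl replaces 2-methoxyphenyl. The larger 11-fold higher number from compound 2 to compound 3 (1.03 log units; beyond the scatter) shows that the group on the carbonyl carbon can shift the read-out strongly, but it changes the substituents as well. On the basis of a 4.6-fold lower number from compound 1 to compound 2 (0.67 log units; beyond the scatter), a modest step towards a lower number is expected in this assay, with a step within the scatter still possible.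

The expected change is a 2.3-fold lower number from compound 3 to compound 4 (0.35 log units; beyond the scatter). For compound 4 the estimated value is 24000 nM. The expected range for compound 4 runs from 9000 nM to 60000 nM.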

Compound 4, concentration for 50% growth inhibition: 51300 nM
Compound 4: the middle estimate sits 2.1-fold (0.33 log units) below what was measured; measured number inside the range.
By their numbers in this assay, from the lowest: compound 2; then compound 1; then compounds 4 and 3 (each within the scatter of the next).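

In this assay, within the data shown here, the exchange of 2-bromophenyl for 3-bromophenyl on a carbonyl carbon gives a 1.1-fold lower number from compound 3 to compound 4 (0.02 log units; within the scatter) and is the first direct read on where a bromo group sits on this phenyl ring: for this pair, the change in placement does not register beyond the scatter. The separation from the methoxy-bearing compounds survives the move, as a 10-fold higher number from compound 2 to compound 4 (1.00 log units; beyond the scatter) and a 2.2-fold higher number from compound 1 to compound 4 (0.34 log units; beyond the scatter) both remain beyond the scatter, so in these compounds the gap follows the exchange of methoxy for bromo groups and not the placement of the bromo group. No measurement offered here gives an explanation for this result.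

Whether methoxy groups tolerate placement changes in the same way stays unresolved, since the step from compound 1 to compound 2 alters their number and their placement together. Also open, on these data alone, is whether the flat response to placement extends to a different kind of substituent on this phenyl ring, such as an amine or a carboxylic acid, and whether any such group would reach numbers lower than those of the methoxy-bearing compounds.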